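The source may hold more compounds than are shown below. What is called first, only, known or untested is meant among the compounds shown, and "the series" means these compounds.

Measured compounds:
compound 1, `COc1ccc2cc(C(C)c3nnc4n3N=C(c3ccc(Cl)cc3Cl)CS4)ccc2c1`, 14600 nM
compound 2, `CC(C)Cc1ccc(C(C)c2nnc3n2N=C(c2ccc(OC(F)(F)F)cc2)CS3)cc1`, 1100 nM

Of the compounds shown here, two sharing one core have been measured in a functional assay on MCF7 cells (Homo sapiens) for inhibition, read by sulforhodamine B assay, with a stated time of 72 h; on this read-out higher numbers stand for weaker inhibition and lower numbers for stronger inhibition. Compound 1 stands at the higher of the two numbers, and compound 2 lies well below it, beyond the usual scatter. Compound 3, `COc1ccc(C2=Nn3c(nnc3C(C)c3ccc4cc(OC)ccc4c3)SC2)cc1`, has not yet been measured. It differs from compound 1 in one place: 4-methoxyphenyl in place of 2,4-dichlorophenyl on a carbon with a double bond to nitrogen. Going by the values given here, no measured pair shows this particular change, so the expectation rests on the two values alone. A modest step downward is expected, a 1.8-fold lower number from compound 1 to compound 3 (0.26 log units; within the scatter), though it may fall within the scatter. Compound 3 is estimated at 8000 nM, with a range from 2500 nM to 25000 nM.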

Compound 3, half-maximal inhibitory concentration: 6600 nM
Beside the measured number, compound 3's estimate is 1.2-fold (0.08 log units) above it; the range from low to high includes it.
By their numbers in this assay, from the lowest: compound 2; then compound 3; then compound 1.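

In this assay, placing 4-methoxyphenyl in place of 2,4-dichlorophenyl on a carbon with a double bond to nitrogen gives a 2.2-fold lower number from compound 1 to compound 3 (0.34 log units; beyond the scatter) with everything else in compound 1 unchanged. This shows that the group at this position can shift the number on its own, though only modestly. No measurement on hand accounts for the step.

The compounds shown leave open how a 4-aminophenyl or 4-carboxyphenyl group would read at this position, and whether the same change would give a similar step on another core.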